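The source may hold more compounds than are shown below. What is called first, only, known or untested is meant among the compounds shown, and "the series" means these compounds.

Working notes on the series. In an ADME assay on cells (Peritoneal macrophage, Mus musculus) for cytotoxicity, read by MTT assay, with a stated time of 24 h (a lower number here means that less compound is tolerated, a higher number that more compound is tolerated), compound 1 `CC(C)(C)c1ccc(N/C(=N\C(=O)c2ccccc2)NCc2ccccc2)cc1` gives 1120000 nM, compound 2 `Cc1ccc(N/C(=N\C(=O)c2ccccc2)NCc2ccccc2)cc1` gives 876000 nM and compound 3 `O=C(/N=C(/NCc1ccccc1)Nc1ccc(C(F)(F)F)cc1)c1ccccc1` gives 18600 nM, so compound 3 stands lowest of the three. The next change leads to compound 4 `O=C(/N=C(/NCc1ccccc1)Nc1ccc(Br)cc1)c1ccccc1`: bromo in place of trifluoromethyl on an aromatic carbon, para to a large group.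

Among the compounds with values here, three measured steps bear on this, all exchanging groups on an aromatic carbon. a 1.3-fold lower number from compound 1 to compound 2 (0.11 log units; within the scatter) stays within the scatter, while a 60-fold lower number from compound 1 to compound 3 (1.78 log units; beyond the scatter) and a 47-fold lower number from compound 2 to compound 3 (1.67 log units; beyond the scatter) are both large. Within the data shown here, only the trifluoromethyl compound stands apart, and no bromo compound has been measured, so the data do not show which side bromo falls on. A rise in this assay is expected on leaving trifluoromethyl, covering part of the gap seen in a 47-fold lower number from compound 2 to compound 3 (1.67 log units; beyond the scatter). The expected size of the change is a 6.5-fold higher number from compound 3 to compound 4 (0.81 log units; beyond the scatter). For compound 4 the estimate is 120000 nM, with an expected range of 20000 nM to 800000 nM.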

Compound 4, half-maximal cytotoxic concentration: 738000 nM
For compound 4 the middle estimate is 6.2-fold (0.79 log units) below the measured one, within the range that was stated.
By their numbers in this assay, from the lowest: compound 3; then compounds 4, 2 and 1 (each within the scatter of the next).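

In this assay, the step of a 40-fold higher number from compound 3 to compound 4 (1.60 log units; beyond the scatter) shows that the low number at this position does not extend to bromo, even though bromo, like trifluoromethyl, replaces the methyl or tert-butyl on the same aromatic carbon. Bromo instead falls with those two groups, with a 1.2-fold lower number from compound 2 to compound 4 (0.07 log units; within the scatter) and a 1.5-fold lower number from compound 1 to compound 4 (0.18 log units; within the scatter), so among the four compounds only the trifluoromethyl of compound 3 stands apart. Nothing available explains why this one group differs from the other three.

Still open, going by these compounds, is whether other groups at this place, such as fluoro, a nitrile or a carboxylic acid, would fall with trifluoromethyl or with the other three. Also open, on these data alone, is whether the gap between trifluoromethyl and bromo would persist with a change elsewhere in the shared core.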